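This account rests on a few compounds, and the source may have more. Where it says the series, first, only, none or still open, it means among the compounds named here.

Series notes. Three compounds of the shared core carry a number in a functional assay on DU-145 cells (Homo sapiens) for inhibition, read by trypan blue exclusion, with a stated time of 96 h; on this read-out lower numbers stand for stronger inhibition of growth and higher numbers for weaker inhibition of growth. Compound 1 `O=C(/C(=C\c1ccc2ccccc2n1)SCc1ccc(F)cc1)c1ccc(Br)cc1` gives 25000 nM in this assay. Among the measured compounds shown here, compound 2 `O=C(/C(=C\c1c[nH]c2ccc(Cl)cc12)SCc1ccc(F)cc1)c1ccc(Br)cc1` gives 1000 nM, and the single measured step here, a 25-fold lower number from compound 1 to compound 2 (1.40 log units; beyond the scatter), is the only change with a value attached. Compound 3 `COc1ccccc1/C=C(/SCc1ccc(F)cc1)C(=O)c1ccc(Cl)cc1` gives 10000 nM in this assay; it stands second highest of the three numbers, nearest to compound 1 and furthest from compound 2.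

The next compound, compound 4 `COc1ccccc1/C=C(/SCc1ccc(F)cc1)C(=O)c1ccc(Br)cc1`, differs from compound 3 in one place: bromo in place of chloro on an aromatic carbon. The place is on an aromatic carbon of a six-membered aromatic ring of carbon only, para to a large group; cut one bond further out, the change reads 4-chlorophenyl to 4-bromophenyl.

For the measured compounds named here, no measured step bears on this change. Compound 1 and compound 2 both carry the bromo group, and compound 3 differs from each of them in more than one place, so their values say nothing about chloro against bromo on its own. The step from compound 1 to compound 2 concerns another part of the molecule. For compound 4 a step of no change at the digits printed from compound 3 to compound 4 (within the scatter) in this assay is therefore expected, that is none beyond the scatter. Compound 4 is estimated at 10000 nM in this assay, within 4000 nM to 25000 nM.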

Compound 4, concentration for 50% growth inhibition: 10000 nM
Estimate against measurement, compound 4: no gap at the digits printed; measured number inside the range.
By their numbers in this assay, from the lowest: compound 2; then compounds 3 and 4 (each within the scatter of the next); then compound 1.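

In this assay, among the compounds shown here, the change from 4-chlorophenyl to 4-bromophenyl gives the first reading at this place, on an aromatic carbon para to a large group: the step is no change at the digits printed from compound 3 to compound 4 (within the scatter) and shows that, with the 2-methoxyphenyl group present, the two halogens cannot be told apart here. For the compounds shown here, with the bromo group held constant, compound 4 also gives the first one-place readings for 2-methoxyphenyl on the double-bonded chain carbon, namely a 10-fold higher number from compound 2 to compound 4 (1.00 log units; beyond the scatter) and a 2.5-fold lower number from compound 1 to compound 4 (0.40 log units; beyond the scatter) in the same assay, which places that group between 5-chloro-1H-indol-3-yl and quinolin-2-yl by number, with both steps beyond the scatter. No measurement at hand accounts for the flat halogen step or for the spread among these three groups.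

From the compounds shown here alone, how a fluoro, a methoxy, an amine or a carboxylic acid on this aromatic carbon would read remains open. Going by these compounds, it also remains open whether chloro and bromo stay level when 5-chloro-1H-indol-3-yl or quinolin-2-yl takes the place of 2-methoxyphenyl.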